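Swapping a side chain on a potent deubiquitinase inhibitor

This account rests on a few compounds, and the source may have more. Where it says the series, first, only, none or still open, it means among the compounds named here.

Of the compounds shown here, three have been measured in an assay on isolated protein for inhibition of ubiquitin carboxyl-terminal hydrolase 7 (Homo sapiens), read by fluorescence, with stated times of 30 min and 1 h; on this read-out lower numbers stand for stronger inhibition and higher numbers for weaker inhibition. Compound 1 `Cc1cc(Cl)cc(-c2ccnc3cc(CN4C(=O)C5CC5C4=O)sc23)c1C[C@@H]1CNC[C@@H](C)O1` gives 0.39 nM, the lowest of the three numbers. Compound 3 `Cc1cc(Cl)cc(-c2ccnc3cc(CN4C(=O)CCC4=O)sc23)c1OC1CCNCC1`, which carries a different side chain and a different imide group on the same core, gives 8 nM, a gap that lies beyond the scatter. Compound 2 `O=C(C1Cc2cc(Cl)cc(-c3ccnc4[nH]ccc34)c2O1)N1CCNCC1`, built on a different core, gives 930 nM, the furthest from compound 1 and also beyond the scatter. No pair of these compounds differs in only one place, so no single step can be read directly from them.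

Compound 4 `Cc1cc(Cl)cc(-c2ccnc3cc(CN4C(=O)C5CC5C4=O)sc23)c1O[C@@H]1CCNC[C@@H]1C` has not yet been measured. It differs from compound 1 in one change, ((3-methylpiperidin-4-yl)oxy in place of (6-methylmorpholin-2-yl)methyl on an aromatic carbon), the side chain of compound 3 with an added methyl group, while the imide of compound 1 is kept. Because compound 3 gives 8 nM with a related side chain and a plainer imide, the step in this assay is expected to be a 1.8-fold higher number from compound 1 to compound 4 (0.25 log units; within the scatter). Compound 4 is estimated at 0.7 nM, within a range from 0.15 nM to 3 nM.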

Compound 4, half-maximal inhibitory concentration: 1.1 nM
Beside the measured number, compound 4's estimate is 1.6-fold (0.20 log units) below it; low and high end bracket the measured number.
By their numbers in this assay, from the lowest: compound 1; then compound 4; then compound 3; then compound 2.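

In this assay, within the data shown here, the one step that can be read is a 2.8-fold higher number from compound 1 to compound 4 (0.45 log units; beyond the scatter), so exchanging (6-methylmorpholin-2-yl)methyl for (3-methylpiperidin-4-yl)oxy on this aromatic carbon, ortho to a methyl group and para to a chloro group, moves the number by a modest but real amount. The two side chains have the same heavy-atom count and the same counts of hydrogen-bond donors and acceptors, and each has a six-membered non-aromatic ring, yet they do not give the same number, so those counts alone do not settle the result at this position. No measured information here accounts for the size of the step, and the compounds shown offer no explanation for it.

Compound 3 differs from compound 4 in both the side chain and the imide, so the separate effects of the added methyl group and the imide cannot be read from these compounds. As far as these compounds go, it also remains open how an open-chain amine, such as a dimethylaminoethyl group, would fare on this same aromatic carbon with the imide of compound 1 kept.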